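Ethynyl in Place of Naphthalen-1-yl: Expected Inhibition

The source may hold more compounds than are shown below. What is called first, only, known or untested is meant among the compounds shown, and "the series" means these compounds.

Measured so far in an ADME assay on GES1 cells (Homo sapiens) for inhibition, read by MTT assay, with a stated time of 72 h; on this read-out higher numbers stand for weaker inhibition and lower numbers for stronger inhibition:
- compound 1 `Cc1cc(Nc2cc(-c3ccccc3)[nH]n2)n2nc(SCc3ccc([N+](=O)[O-])cc3)nc2n1` gives 43600 nM
- compound 2 `Cc1cc(Nc2cc(-c3ccccc3)[nH]n2)n2nc(SCc3c(Cl)cccc3Cl)nc2n1` gives 39600 nM
- compound 3 `Cc1cc(Nc2cc(-c3ccccc3)[nH]n2)n2nc(SCc3cccc4ccccc34)nc2n1` gives 36300 nM

Compound 3 carries the lowest of the three numbers, but the others sit close: a 1.1-fold lower number from compound 2 to compound 3 (0.04 log units; within the scatter) and a 1.2-fold lower number from compound 1 to compound 3 (0.08 log units; within the scatter), both within the scatter, so no order among the three can be claimed. Compound 4 `C#CCSc1nc2nc(C)cc(Nc3cc(-c4ccccc4)[nH]n3)n2n1` differs from compound 3 at one place: ethynyl in place of naphthalen-1-yl on a saturated chain carbon bound to a sulfur. Going by the values given here, every measured step so far exchanges one aromatic group for another at that same place, including a 1.1-fold lower number from compound 1 to compound 2 (0.04 log units; within the scatter), and none moved the number beyond the scatter. Nothing measured here trades an aromatic group for a short chain such as ethynyl, so the expectation rests only on how steady the three numbers have been. Compound 4 is therefore estimated to give 45000 nM, with a range from 20000 nM to 100000 nM, which would mean an expected step of a 1.2-fold higher number from compound 3 to compound 4 (0.09 log units; within the scatter).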

Compound 4, half-maximal inhibitory concentration: 45700 nM
Estimate against measurement, compound 4: 1.0-fold (0.01 log units) below; measured number inside the range.
By their numbers in this assay, from the lowest: compounds 3, 2, 1 and 4 (each within the scatter of the next).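

The earlier steps shown here only swapped one aromatic group for another at this place, on a saturated chain carbon bound to a sulfur. Here a small ethynyl with no ring and 2 heavy atoms replaces each of those groups, and in this assay every step stays within the scatter (a 1.3-fold higher number from compound 3 to compound 4 (0.10 log units; within the scatter); a 1.2-fold higher number from compound 2 to compound 4 (0.06 log units; within the scatter); a 1.0-fold higher number from compound 1 to compound 4 (0.02 log units; within the scatter)). No measurement here explains this flatness.
Going by these compounds, whether an amine or a carboxylic acid at this place would move the number beyond the scatter stays open.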